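A few compounds are considered here, and "the series" means these few. Any claim that something is new, unique, unknown or untested is made for them only; others in the source may bear on it.

Compound 1 `COc1cc(/C(Cl)=C/C=C(\C#N)C(=O)c2c[nH]c3ccccc23)cc(OC)c1OC` is the reference point in this set. In an ADME assay on Vero cells (Chlorocebus sabaeus) for cytotoxicity, read by sulforhodamine B assay, with a stated time of 48 h (a lower number here means that less compound is tolerated, a higher number that more compound is tolerated), compound 1 gives 54200 nM. Going by the values given here, compound 2 `COc1ccc(/C(Cl)=C/C=C(\C#N)C(=O)c2c(C)[nH]c3ccccc23)cc1` carries only a single methoxy group on its aryl ring, but in this assay compound 2 gives "not determined" (no result reported), so it contributes no number. Compound 3 `COc1cc(/C(Cl)=C/C=C(\C#N)C(=O)c2c[nH]c3ccc(Br)cc23)cc(OC)c1OC` differs from compound 1 only by a bromo in place of hydrogen on an aromatic carbon, and in this assay compound 3 gives 41500 nM. Among the compounds with values here, the step of a 1.3-fold lower number from compound 1 to compound 3 (0.12 log units; within the scatter) is within the scatter, so compound 3 and compound 1 cannot be told apart on these numbers, and compound 3 stands alongside the only other compound that has a number.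

Compound 4 `COc1ccc(/C(Cl)=C/C=C(\C#N)C(=O)c2c[nH]c3ccc(Br)cc23)cc1OC` is next. Relative to compound 3 the change is hydrogen in place of methoxy on an aromatic carbon. Within the data shown here, no measured step tests this change: the one step that exists, from compound 1 to compound 3, concerns a bromo and was within the scatter, and compound 2, the only compound with fewer methoxy groups, has no number. With nothing pointing in either direction, the expected step of a 1.1-fold higher number from compound 3 to compound 4 (0.04 log units; within the scatter) is none beyond the scatter. Compound 4 is therefore estimated at 45000 nM, with a range from 20000 nM to 100000 nM.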

Compound 4, concentration lethal to 50% of the cells: 51800 nM
For compound 4 the middle estimate is 1.2-fold (0.06 log units) below the measured one; the range from low to high includes it.
By their numbers in this assay, from the lowest: compounds 3, 4 and 1 (each within the scatter of the next).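

Replacing a methoxy group with hydrogen now has a direct reading in this assay: the step is a 1.2-fold higher number from compound 3 to compound 4 (0.10 log units; within the scatter) and shows that, at this place on the six-membered aromatic ring of carbon only, ortho to a methoxy group and meta to a large group, the two compounds cannot be told apart on these numbers. Before this, the only readable step concerned a bromo, so this pair gives the first measured comparison for a methoxy group on this ring, although it comes from compounds that both carry the bromo. No evidence is available to explain this result.

The compounds shown leave open whether hydrogen in place of methoxy would read the same way in the absence of the bromo, or at the other methoxy positions on this ring. They also leave open what a group other than hydrogen or methoxy, such as an amine or a carboxylic acid, would give at this place in this assay.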